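Exposure after swapping the aryl ether for a benzoyl group

The source may report more compounds than this note shows. Statements on the series, on what has been measured and on what is new or still open speak of the compounds shown alone.

Compound 2 `Cc1cn(-c2cc(NC(=O)c3ccc(C)c(Oc4cccc5ccncc45)c3)cc(N3CCN(C)CC3)c2)cn1` stands at the lower end of the two numbers seen so far in an ADME assay on the whole organism (Mus musculus, strain CD1), read by LC-MS, using cassette dosing, with a stated time of 24 h, at a dose of 0.4 mg/kg by the intravenous route; on this read-out higher numbers stand for higher exposure at the dose given and lower numbers for lower exposure: compound 2 gives 128 ng.h/mL, while compound 1 `Cc1cn(-c2cc(NC(=O)c3ccc(C)c(Oc4ccccc4)c3)cc(N3CCN(C)CC3)c2)cn1` gives 338 ng.h/mL. Within the data shown here, the only measured step, a 2.6-fold lower number from compound 1 to compound 2 (0.42 log units; beyond the scatter), shows that a change at this position can move exposure modestly. Compound 3 `Cc1cn(-c2cc(NC(=O)c3ccc(C)c(C(=O)c4cccc(C#N)c4)c3)cc(N3CCN(C)CC3)c2)cn1` differs from compound 2 by (3-cyanophenyl)carbonyl in place of (isoquinolin-8-yl)oxy on an aromatic carbon. Among the measured compounds shown here, no measured step covers this pair directly; the one step that bears on it, from compound 1 to compound 2, was of modest size and downward, so a change of similar scale in either direction, or none beyond the scatter, is expected here. Compound 3 is estimated at 220 ng.h/mL in this assay, within a range from 80 ng.h/mL to 600 ng.h/mL, which corresponds to an expected step of a 1.7-fold higher number from compound 2 to compound 3 (0.24 log units; within the scatter).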

Compound 3, area under the concentration-time curve: 78 ng.h/mL
For compound 3 the middle estimate is 2.8-fold (0.45 log units) above the measured one, outside the stated range (below it).
By their numbers in this assay, from the lowest: compounds 3 and 2 (each within the scatter of the next); then compound 1.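

In this assay, putting (3-cyanophenyl)carbonyl in place of (isoquinolin-8-yl)oxy on this aromatic carbon gives a 1.6-fold lower number from compound 2 to compound 3 (0.22 log units; within the scatter) and so does not separate these two groups. The same group in place of phenoxy gives a 4.3-fold lower number from compound 1 to compound 3 (0.64 log units; beyond the scatter) and thus a larger step than the one seen with the isoquinoline ether, leaving the phenoxy compound 1 clear of both others at this position. Nothing measured here accounts for these differences.

As far as these compounds go, it remains open whether the nitrile matters, since a plain benzoyl group could read either like compound 3 or like compound 1. From the compounds shown here alone, it is equally open whether a phenoxy group carrying an amine or a carboxylic acid would stay near compound 1 or fall towards the other two.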